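Adding a Second Benzyl Group to the Amine of Compound 3

The source may report more compounds than this note shows. Statements on the series, on what has been measured and on what is new or still open speak of the compounds shown alone.

Compound 3 `Cc1ccn2cc(-c3ccc(NCc4ccccc4)cc3)nc2c1` gives 5100 nM in a functional assay on A549 cells (Homo sapiens) for antiproliferative activity, read by MTT assay, with a stated time of 72 h (on this read-out lower numbers stand for stronger inhibition of growth and higher numbers for weaker inhibition of growth), the lowest of the three numbers measured. For the measured compounds named here, compound 2 `Cc1ccn2cc(-c3ccc([N+](=O)[O-])cc3)nc2c1` gives 62400 nM, and the step of a 12-fold lower number from compound 2 to compound 3 (1.09 log units; beyond the scatter) is the only single-point change measured so far. Compound 1 `Cc1ccc2nc(-c3ccc(N(Cc4ccccc4)Cc4ccccc4)cc3)cn2c1`, which carries two benzyl groups on the amine but a different core, gives 60000 nM. Compound 4 `Cc1ccn2cc(-c3ccc(N(Cc4ccccc4)Cc4ccccc4)cc3)nc2c1` differs from compound 3 by benzyl in place of hydrogen on a nitrogen on an aromatic ring. Going by the values given here, no measured step matches this change, so the expectation rests on compound 1, whose value 60000 nM sits far above that of compound 3. Compound 4 is therefore expected to show a higher number, a step of about a 5.9-fold higher number from compound 3 to compound 4 (0.77 log units; beyond the scatter). The estimate for compound 4 is 30000 nM, with a range from 8000 nM to 100000 nM.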

Compound 4, concentration for 50% growth inhibition: 17200 nM
Beside the measured number, compound 4's estimate is 1.7-fold (0.24 log units) above it, within the range that was stated.
By their numbers in this assay, from the lowest: compound 3; then compound 4; then compounds 1 and 2 (each within the scatter of the next).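

Putting a second benzyl group on the amine nitrogen weakens growth inhibition in this assay, with a 3.4-fold higher number from compound 3 to compound 4 (0.53 log units; beyond the scatter), so at this position the nitrogen tolerates the extra benzyl group but loses some activity. With both benzyl groups kept, the core also counts, giving a 3.5-fold lower number from compound 1 to compound 4 (0.54 log units; beyond the scatter). Nothing available explains either step.

From the compounds shown here alone, it remains open how a smaller group such as methyl, or a longer chain such as phenethyl, would behave on this nitrogen. Whether an acetyl group there would keep the activity of compound 3 is also unknown.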